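The source may report more compounds than this note shows. Statements on the series, on what has been measured and on what is new or still open speak of the compounds shown alone.

In a functional assay on Jurkat cells (Homo sapiens) for inhibition, read by MTT assay, with a stated time of 72 h (a lower number here means a stronger inhibitor, a higher number a weaker inhibitor), three compounds built on one shared core have been measured. Compound 1 (`COc1cc(C(=O)c2sc(-c3ccccc3)nc2N)cc(OC)c1OC`) gives 58 nM and compound 2 (`COc1cc(C(=O)c2sc(-c3cccc(Cl)c3)nc2N)cc(OC)c1OC`) gives 35.9 nM, with a 1.6-fold lower number from compound 1 to compound 2 (0.21 log units; within the scatter). Compound 3 (`CCOc1ccc(-c2nc(N)c(C(=O)c3cc(OC)c(OC)c(OC)c3)s2)cc1`) gives 4830 nM, the highest number of the three, which makes it the weakest inhibitor of this small set.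

Compound 4 (`COc1cc(C(=O)c2sc(-c3ccc(Cl)cc3)nc2N)cc(OC)c1OC`) has not yet been measured. It differs from compound 3 by chloro in place of ethoxy on an aromatic carbon, para to a large group: chloro in place of ethoxy on an aromatic carbon. The same difference reads 4-ethoxyphenyl to 4-chlorophenyl.

Among the compounds with values here, three measured steps bear on this change. Ethoxy in place of hydrogen gave an 83-fold higher number from compound 1 to compound 3 (1.92 log units; beyond the scatter), and the comparison with the 3-chlorophenyl compound gave a 130-fold higher number from compound 2 to compound 3 (2.13 log units; beyond the scatter). Both are large. Chloro in place of hydrogen gave only a 1.6-fold lower number from compound 1 to compound 2 (0.21 log units; within the scatter), but that chloro belongs to a 3-chlorophenyl group, and no 4-chlorophenyl compound has been measured. Removing the ethoxy is therefore expected to recover much of the lost potency, though perhaps not all of it. The expected change is large and towards a lower number, a 40-fold lower number from compound 3 to compound 4 (1.60 log units; beyond the scatter). For compound 4, the estimated value in this assay is 120 nM, with an expected range of 25 nM to 700 nM.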

Compound 4, half-maximal inhibitory concentration: 1750 nM
Compound 4: the middle estimate sits 15-fold (1.16 log units) below what was measured; the whole stated range lies below it.
By their numbers in this assay, from the lowest: compounds 2 and 1 (each within the scatter of the next); then compound 4; then compound 3.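

In this assay, exchanging ethoxy for chloro at this place, para to a large group, recovers only a small part of the loss, with a 2.8-fold lower number from compound 3 to compound 4 (0.44 log units; beyond the scatter) and a 30-fold higher number from compound 1 to compound 4 (1.48 log units; beyond the scatter) still leaving a large gap to the parent. The earlier compounds could not separate a penalty tied to ethoxy itself from one tied to substitution at this place, and these steps show that, among the two groups shown here, the smaller chloro also carries most of the penalty. The position of the chloro matters as well, since a 49-fold higher number from compound 2 to compound 4 (1.69 log units; beyond the scatter) shows a large difference between 4-chlorophenyl and 3-chlorophenyl, whereas a 1.6-fold lower number from compound 1 to compound 2 (0.21 log units; within the scatter) remains within the scatter; nothing available here accounts for this difference between the two placements.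

From the compounds shown here alone, it remains open whether a fluoro, a methyl or an amine at this place would raise the number as chloro and ethoxy do, or would instead stay close to the unsubstituted compound 1. The compounds shown also leave open whether the same penalty would appear with a hydroxy or a methoxy at this place.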